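This account rests on a few compounds, and the source may have more. Where it says the series, first, only, none or still open, it means among the compounds named here.

Compound 1 `CCCCCCCCNc1nc(SCc2ccc(C(F)(F)F)cc2)nc2ccccc12` gives 12600 nM in a functional assay on MGC-803 cells (Homo sapiens) for cytotoxicity, read by MTT assay, with a stated time of 72 h (on this read-out higher numbers stand for weaker inhibition and lower numbers for stronger inhibition), and stands as the lowest of the two numbers shown. Compound 2 `FC(F)(F)c1ccc(CSc2nc(Nc3ccccc3)c3ccccc3n2)cc1` gives 22200 nM in this assay, a step of a 1.8-fold higher number from compound 1 to compound 2 (0.25 log units; within the scatter). For compound 3 `FC(F)(F)c1ccc(CSc2nc(Nc3ccccc3Cl)c3ccccc3n2)cc1` this assay reports only a limit, > 50000 nM. From compound 1 that step is an at least 3.9-fold higher number from compound 1 to compound 3 (0.59 log units; beyond the scatter), and from compound 2 it is an at least 2.2-fold higher number from compound 2 to compound 3 (0.35 log units; beyond the scatter); both rest on (the limit of > 50000 nM in this assay, at which 1 of the 3 values shown sits). Compound 4 `Cc1ccccc1Nc1nc(SCc2ccc(C(F)(F)F)cc2)nc2ccccc12` differs from compound 1 by 2-methylphenyl in place of octyl on a nitrogen on an aromatic ring. The phenyl replacement of octyl stays within the scatter while the 2-chlorophenyl one goes beyond it, so for compound 4 a step towards weaker inhibition of about a 2.8-fold higher number from compound 1 to compound 4 (0.44 log units; beyond the scatter) is expected in this assay, with a real chance that only a limit is returned. Compound 4 is therefore estimated at 35000 nM, with a range of 15000 nM to 80000 nM.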

Compound 4, half-maximal inhibitory concentration: 24400 nM
Estimate against measurement, compound 4: 1.4-fold (0.16 log units) above; measured number inside the range.
By their numbers in this assay, from the lowest: compounds 1, 2 and 4 (each within the scatter of the next). At a limit, above all of these: compound 3.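

In this assay, 2-methylphenyl in place of octyl on the nitrogen gives a 1.9-fold higher number from compound 1 to compound 4 (0.29 log units; within the scatter), so this aromatic group, like phenyl, cannot be told apart from the octyl chain. Methyl in place of hydrogen on the aromatic carbon gives a 1.1-fold higher number from compound 2 to compound 4 (0.04 log units; within the scatter), so this substitution as such does not separate the compounds. The identity of the group on that carbon does count, as methyl in place of chloro gives an at least 2.0-fold lower number from compound 3 to compound 4 (0.31 log units; beyond the scatter), a step that rests on a limit for compound 3: the limit of > 50000 nM in this assay, at which 1 of the 4 values shown sits.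

From the compounds shown here alone, whether fluoro or methoxy on that aromatic carbon tracks with methyl or with chloro stays open. So does whether a butyl chain or a benzyl group on the nitrogen would fall with octyl.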